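Branching the Chain on the Core: Propyl to sec-Butyl

The compounds below may be only part of what the source reports. "The series", "measured", "known", "first", "only" and "open" are said of these compounds alone.

Compound 1 `COc1ccc(Br)cc1CCc1c(Cl)cccc1-c1nccn1C`: 1100 nM in a functional assay on HEK293 cells (Homo sapiens), read by cAMP accumulation; on this read-out higher numbers stand for weaker inhibition and lower numbers for stronger inhibition
Compound 2 `CCn1ccnc1-c1cccc(Cl)c1CCc1cc(Br)ccc1OC`: 1800 nM
Compound 3 `CCCn1ccnc1-c1cccc(Cl)c1CCc1cc(Br)ccc1OC`: 1900 nM

Compound 3 cannot be told apart from the other two members of this small set: a 1.7-fold higher number from compound 1 to compound 3 (0.24 log units; within the scatter) and a 1.1-fold higher number from compound 2 to compound 3 (0.02 log units; within the scatter) both fall within the usual scatter.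

Compound 4 `CCC(C)n1ccnc1-c1cccc(Cl)c1CCc1cc(Br)ccc1OC` differs from compound 3 by methyl in place of hydrogen on a saturated chain carbon bound to an aromatic nitrogen and a saturated chain carbon. Among the measured compounds shown here, the steps that bear on this are those that also added carbon to the chain on the aromatic nitrogen: a 1.6-fold higher number from compound 1 to compound 2 (0.21 log units; within the scatter), a 1.7-fold higher number from compound 1 to compound 3 (0.24 log units; within the scatter) and, one bond further out, a 1.1-fold higher number from compound 2 to compound 3 (0.02 log units; within the scatter). None of them moved the number beyond the scatter, so no step beyond the scatter is expected here either in this assay.

For compound 4 the expected value is therefore 2300 nM, within a range of 900 nM to 6000 nM, which means an expected step of a 1.2-fold higher number from compound 3 to compound 4 (0.08 log units; within the scatter).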

Compound 4, half-maximal inhibitory concentration: 2100 nM
The estimate for compound 4 lay 1.1-fold (0.04 log units) above the measured number; low and high end bracket the measured number.
By their numbers in this assay, from the lowest: compounds 1, 2, 3 and 4 (each within the scatter of the next).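

Putting a branch on the saturated chain carbon bound to an aromatic nitrogen gives a 1.1-fold higher number from compound 3 to compound 4 (0.04 log units; within the scatter) in this assay and shows that this position takes a branched chain much as it takes straight ones. Set against the ethyl and methyl compounds, sec-butyl gives a 1.2-fold higher number from compound 2 to compound 4 (0.07 log units; within the scatter) and a 1.9-fold higher number from compound 1 to compound 4 (0.28 log units; within the scatter) in turn, so even this widest comparison stays within the scatter. Adding the same methyl to a shorter or a longer chain gives steps that agree within the scatter: the same change on two cores in this assay, a 1.6-fold higher number (0.21 log units; within the scatter) from compound 1 to compound 2 and a 1.1-fold higher number (0.04 log units; within the scatter) from compound 3 to compound 4, 1.5-fold (0.17 log units) apart, within the scatter of two such steps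

Every group shown on this aromatic nitrogen is a simple saturated chain. Going by these compounds, whether a cyclopropyl ring, a benzyl group or a chain ending in an amine or a carboxylic acid would move the number beyond the scatter remains open.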